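Series notes: 4-methylphenyl in place of methyl

This account rests on a few compounds, and the source may have more. Where it says the series, first, only, none or still open, it means among the compounds named here.

Of the compounds shown here, three have been measured in a functional assay on MDA-MB-231 cells (Homo sapiens) for antiproliferative activity, read by CCK-8 assay, with a stated time of 48 h; a higher number here means a weaker inhibitor, a lower number a stronger inhibitor. Compound 1 `Cc1ccc(-c2[nH]c3ccccc3c2C2=C(Br)C(=O)C(Br)=C(Br)C2=O)cc1` gives 21.6 ug/mL. Compound 2 `Cc1ccc(-c2[nH]c3ccccc3c2C2=C(Cl)C(=O)C(c3c(C)[nH]c4ccccc34)=C(Cl)C2=O)cc1` gives 4.21 ug/mL. Compound 3 `Cc1[nH]c2ccccc2c1C1=C(Br)C(=O)C(Br)=C(c2c(C)[nH]c3ccccc23)C1=O` gives 4.76 ug/mL. Among these three numbers compound 3 stands second highest; its nearest neighbour is compound 2, which lies within the scatter, and its furthest is compound 1, whose higher number lies beyond the scatter.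

Compound 4 `Cc1ccc(-c2[nH]c3ccccc3c2C2=C(Br)C(=O)C(Br)=C(c3c(C)[nH]c4ccccc34)C2=O)cc1` has not been measured. It differs from compound 3 in one place: 4-methylphenyl in place of methyl on an aromatic carbon. Among the measured compounds shown here, no pair of measured compounds reproduces this change on its own. For the measured compounds named here, compound 1, the only measured compound that carries the 4-methylphenyl, shows the higher number when set beside compound 3, yet it also differs from compound 3 elsewhere. A modest move toward a higher number is therefore the working expectation, one that need not exceed the scatter. Compound 4 is expected to give 6.5 ug/mL in this assay, within the range 2.5 ug/mL to 16 ug/mL. The expected step of a 1.4-fold higher number from compound 3 to compound 4 (0.14 log units; within the scatter) is small.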

Compound 4, half-maximal inhibitory concentration: 5.89 ug/mL
Compound 4: the middle estimate sits 1.1-fold (0.04 log units) above what was measured, and the stated range covers the measured number.
By their numbers in this assay, from the lowest: compounds 2, 3 and 4 (each within the scatter of the next); then compound 1.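

In this assay the change of methyl to 4-methylphenyl on this aromatic carbon, next to the ring nitrogen, can now be read on its own: it gives a 1.2-fold higher number from compound 3 to compound 4 (0.09 log units; within the scatter) and so leaves the number within the scatter with either group in place. Among the compounds shown here, with the 4-methylphenyl held constant, 2-methyl-1H-indol-3-yl in place of bromo on a double-bonded ring carbon gives a 3.7-fold lower number from compound 1 to compound 4 (0.56 log units; beyond the scatter) and is the only one of the two changes that moves the number beyond the scatter. No measurement at hand offers a reason for either step.

From the compounds shown here alone, all groups compared at this position contain carbon only, so it remains open whether an amine or a carboxylic acid on the phenyl ring would be held as well. Going by these compounds, whether a longer chain in place of methyl behaves like these two groups also remains open.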